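The compounds below may be only part of what the source reports. "The series", "measured", "known", "first", "only" and "open" are said of these compounds alone.

Compound 2 `CCOc1ccccc1C(=O)Nc1nc(-c2ccccc2)nc2c1nnn2Cc1ccccc1` gives 1850 nM in an assay (strain Wistar) for displacement of a labelled ligand from adenosine receptor A1 (Rattus norvegicus), read by scintillation counting (on this read-out lower numbers stand for stronger inhibition and higher numbers for weaker inhibition), the highest of the three numbers measured. Compound 1 `O=C(Nc1nc(-c2ccccc2)nc2c1nnn2Cc1ccccc1)c1cccc(F)c1` gives 22 nM in this assay, and compound 3 `O=C(Nc1nc(-c2ccccc2)nc2c1nnn2Cc1ccccc1)c1cccc([N+](=O)[O-])c1` gives 77 nM. Compound 4 `O=C(Nc1nc(-c2ccccc2)nc2c1nnn2Cc1ccccc1)C1CC1` carries a different group at the same position: cyclopropyl in place of 2-ethoxyphenyl on a carbonyl carbon. Going by the values given here, two measured steps bear on this change, since each exchanges the 2-ethoxyphenyl for another group on the carbonyl carbon: a 24-fold lower number from compound 2 to compound 3 (1.38 log units; beyond the scatter) and an 84-fold higher number from compound 1 to compound 2 (1.92 log units; beyond the scatter). Both are large, and both place the 2-ethoxyphenyl at the weaker end. Among the compounds with values here, no measured compound carries cyclopropyl, so the size is uncertain, but a large step toward a lower number is expected, a 12-fold lower number from compound 2 to compound 4 (1.09 log units; beyond the scatter). Compound 4 is therefore estimated at 150 nM, between 30 nM and 900 nM.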

Compound 4, inhibition constant: 7.5 nM
Estimate against measurement, compound 4: 20-fold (1.30 log units) above; measured number outside the range, below it.
By their numbers in this assay, from the lowest: compound 4; then compound 1; then compound 3; then compound 2.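

The earlier compounds shown here held only substituted phenyl groups on this carbonyl carbon, so they could not show that a six-membered aromatic ring is not needed there. In this assay, the three-membered non-aromatic ring of cyclopropyl gives the lowest number of the four, with a 2.9-fold lower number from compound 1 to compound 4 (0.47 log units; beyond the scatter), a 10-fold lower number from compound 3 to compound 4 (1.01 log units; beyond the scatter) and a 250-fold lower number from compound 2 to compound 4 (2.39 log units; beyond the scatter). Nothing available explains why this exchange lowers the number.

The compounds shown leave open whether this holds for other carbon groups on the carbonyl carbon, such as cyclobutyl, cyclohexyl or a longer chain. They also leave open how an unsubstituted phenyl would compare.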